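The source may report more compounds than this note shows. Statements on the series, on what has been measured and on what is new or still open speak of the compounds shown alone.

Measured compounds:
Compound 1, `CCCCCCCOc1cc(-c2ccccc2)c(-c2ccccc2)nn1` — in an assay on microsomes from liver for inhibition of sterol O-acyltransferase 1 (Rattus norvegicus) (on this read-out lower numbers stand for stronger inhibition and higher numbers for weaker inhibition), compound 1 gives 58000 nM.
Compound 2, `CCCCCCS(=O)(=O)c1cc(-c2ccccc2)c(-c2ccccc2)nn1` — in this assay compound 2 gives 60000 nM.
Compound 3, `CCCCCCCCS(=O)(=O)c1cc(-c2ccccc2)c(-c2ccccc2)nn1` — in this assay compound 3 gives 36000 nM.

Compound 3 gives the lowest of the three numbers, but its gaps to compound 1 and to compound 2 both lie within the scatter, so the three compounds cannot be ordered on these data. Compound 4, `CCCCCCCCCS(=O)(=O)c1cc(-c2ccccc2)c(-c2ccccc2)nn1`, is not yet measured. It differs from compound 3 by methyl in place of hydrogen on a saturated chain carbon, eight bonds along the chain from a sulfonyl sulfur. Among the compounds with values here, one measured step bears on this change directly: a chain extension in a 1.7-fold lower number from compound 2 to compound 3 (0.22 log units; within the scatter), which stayed within the scatter. The exchange of the side group in a 1.0-fold higher number from compound 1 to compound 2 (0.01 log units; within the scatter) also left the number essentially unchanged. On this basis a further single-carbon extension of the chain is expected to move the number little, with at most a slight drift downward, estimated as a 1.2-fold lower number from compound 3 to compound 4 (0.08 log units; within the scatter). Compound 4 is therefore expected to give about 30000 nM in this assay, in a range from 12000 nM to 75000 nM.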

Compound 4, half-maximal inhibitory concentration: 76000 nM
The estimate for compound 4 lay 2.5-fold (0.40 log units) below the measured number; measured number above the stated range.
By their numbers in this assay, from the lowest: compounds 3, 1, 2 and 4 (each within the scatter of the next, the first and the last beyond it).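

In this assay, within the data shown here, methyl in place of hydrogen on the saturated chain carbon eight bonds along the chain from a sulfonyl sulfur gave a 2.1-fold higher number from compound 3 to compound 4 (0.32 log units; beyond the scatter) and so produced the only step here beyond the scatter. This position therefore responds to one added carbon, and the response runs opposite to the within-scatter drift seen one change earlier. Taken from the shorter chain, the whole extension gave a 1.3-fold higher number from compound 2 to compound 4 (0.10 log units; within the scatter) and left those two compounds indistinguishable, so the chain lengths shown trace no steady trend. Nothing measured here accounts for the rise. The compounds shown leave open whether a longer chain would keep the number at this level or move it further, and whether an amine or a carboxylic acid at the chain end would lower it.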